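Turning the methoxy group of compound 1 into benzyloxy

A few compounds are considered here, and "the series" means these few. Any claim that something is new, unique, unknown or untested is made for them only; others in the source may bear on it.

In a functional assay on DU-145 cells (Homo sapiens) for inhibition, read by trypan blue exclusion, with a stated time of 96 h (on this read-out lower numbers stand for stronger inhibition of growth and higher numbers for weaker inhibition of growth), compound 1 `COc1ccccc1/C=C(/SCc1ccc(F)cc1)C(=O)c1ccc(Br)cc1` gives 10000 nM as its value. Among the compounds with values here, compound 2 `O=C(/C(=C\c1ccc(O)cc1)SCc1ccc(F)cc1)c1ccc(Br)cc1` gives 10000 nM in this assay as well, so compound 1 stands level with its only measured neighbour.

Compound 3 `O=C(/C(=C\c1ccccc1OCc1ccccc1)SCc1ccc(F)cc1)c1ccc(Br)cc1` keeps the core of compound 1 and alters a single group. The difference is phenyl in place of hydrogen on a saturated chain carbon bound to an oxygen on an aromatic ring and, read one bond further out, it turns methoxy into benzyloxy.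

Within the data shown here, only one measured step bears on this, and only loosely. The step of no change at the digits printed from compound 1 to compound 2 (within the scatter) came with 4-hydroxyphenyl in place of 2-methoxyphenyl, so replacing that aryl group left the number where it was. Among the measured compounds shown here, no measured compound carries the added phenyl, so the data do not test this change directly.

Resting on the flat step no change at the digits printed from compound 1 to compound 2 (within the scatter) alone, no shift in either direction beyond the scatter is expected in this assay. The expected outcome is no change at the digits printed from compound 1 to compound 3 (within the scatter) and this remains an uncertain estimate. Compound 3 is estimated at 10000 nM with an expected range from 3000 nM to 20000 nM in all.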

Compound 3, concentration for 50% growth inhibition: 1000 nM
The estimate for compound 3 lay 10-fold (1.00 log units) above the measured number; the measured number lies below the stated range.
By their numbers in this assay, from the lowest: compound 3; then compounds 1 and 2 (each within the scatter of the next).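

Within the data shown here, the earlier pair showed only that one aryl group could replace another with no visible effect on the number. Compound 3 shows that the methoxy group of compound 1 is not a place where every change goes unnoticed: turning methoxy into benzyloxy gives a 10-fold lower number from compound 1 to compound 3 (1.00 log units; beyond the scatter) in this assay, and a lower number here stands for stronger inhibition of growth. Among these compounds, this is a modest step, and the only thing that changes in it is a phenyl in place of hydrogen on a saturated chain carbon bound to an oxygen on an aromatic ring, but no measurement at hand accounts for the link between that phenyl and the lower number.

The compounds shown leave open whether the phenyl ring itself matters, or whether a plain chain such as butoxy in the place of benzyloxy would give the same lower number. They also leave open how much room this group allows, for example whether a longer link as in 2-phenylethoxy, or an amine or a carboxylic acid on the added phenyl, would keep the gain.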